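Bromine-to-hydroxy swap on the core of compound 1

The source may report more compounds than this note shows. Statements on the series, on what has been measured and on what is new or still open speak of the compounds shown alone.

Compound 1 `O=c1cc(-n2cc(COc3ccccc3)nn2)c2cc(Br)ccc2o1` stands lowest of the two numbers in a functional assay on SW480 cells (Homo sapiens) for antiproliferative activity, read by MTT assay, with a stated time of 48 h (a lower number here means a stronger inhibitor, a higher number a weaker inhibitor), where compound 1 gives 4990 nM; in this assay compound 2 `O=c1cc(-n2cc(COc3ccccc3O)nn2)c2cc(Br)ccc2o1` gives 19100 nM, the step of a 3.8-fold higher number from compound 1 to compound 2 (0.58 log units; beyond the scatter). Compound 3 `O=c1cc(-n2cc(COc3ccccc3)nn2)c2cc(O)ccc2o1` differs from compound 1 by hydroxy in place of bromo on an aromatic carbon. Among the compounds with values here, no measured step bears on this change directly; the only step, a 3.8-fold higher number from compound 1 to compound 2 (0.58 log units; beyond the scatter), put a hydroxy on the phenoxy ring and weakened the compound modestly. A weakening step of similar size is expected here, a 3.0-fold higher number from compound 1 to compound 3 (0.48 log units; beyond the scatter), so compound 3 is estimated at 15000 nM in this assay, range 5000 nM to 45000 nM.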

Compound 3, half-maximal inhibitory concentration: > 50000 nM
Compound 3: only a limit was reported (the forecaster's own chance of this, stated with the estimate: 10%); middle value at least 3.3-fold (0.52 log units) from the limit.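

The earlier step touched only the phenoxy ring; this one shows that the aromatic carbon carrying bromo on the shared core also matters in this assay. Hydroxy in place of bromo there gives an at least 10-fold higher number from compound 1 to compound 3 (1.00 log units; beyond the scatter), so this swap costs activity. For compound 3 the reported value is a limit, so the step has no upper end: the limit of > 50000 nM in this assay, at which 1 of the 3 values shown sits.

On these data alone, whether the loss comes from losing bromo or from gaining hydroxy stays open. A compound with hydrogen, chloro or methoxy at this carbon would separate the two.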